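Adding a (dimethylamino)methyl group to compound 1

The compounds below may be only part of what the source reports. "The series", "measured", "known", "first", "only" and "open" are said of these compounds alone.

In a functional assay on P388 cells (Mus musculus) (on this read-out lower numbers stand for stronger inhibition and higher numbers for weaker inhibition), compound 1 `O=C(/C=C/c1ccc(F)cc1)Oc1ccc(/C=C2\CCCCC2=O)cc1` gives > 50000 nM, which is a limit and not a number. Compound 2 `O=C(/C=C/c1ccc(Br)cc1)Oc1ccc(/C=C2\CCCCC2=O)cc1` gives > 50000 nM, again a limit. Compound 3 `O=C(/C=C/c1ccc(Cl)c(Cl)c1)Oc1ccc(/C=C2\CCCCC2=O)cc1` gives > 50000 nM, also a limit. Compound 1 therefore shares its place with the other two, namely the limit of > 50000 nM in this assay, at which 3 of the 3 values shown sit, and no more exact reading.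

Compound 4 `CN(C)CC1CCC/C(=C\c2ccc(OC(=O)/C=C/c3ccc(F)cc3)cc2)C1=O` has not yet been measured in this assay. It differs from compound 1 by (dimethylamino)methyl in place of hydrogen on a saturated ring carbon.

The measured steps offer little guidance. They are a step that the two limits leave unreadable from compound 1 to compound 2, a step that the two limits leave unreadable from compound 1 to compound 3 and a step that the two limits leave unreadable from compound 2 to compound 3, and all three concern the halogens on the aromatic end, with none touching a saturated ring carbon. They provide no size to carry over, so the expectation rests on the structural change alone, and compound 4 may well remain at a limit too. The expected change is an at least 6.2-fold lower number from compound 1 to compound 4 (0.79 log units; beyond the scatter) in the direction of stronger inhibition, though this estimate is a loose one. For compound 4 the estimated value is 8000 nM, with an expected range from 1500 nM to 45000 nM.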

Compound 4, half-maximal inhibitory concentration: 4550 nM
Compound 4: the middle estimate sits 1.8-fold (0.25 log units) above what was measured; the measured number falls inside the stated range.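

In this assay, going by these compounds alone, the new result gives the first step in this set whose size can be read, and it is large: an at least 10-fold lower number from compound 1 to compound 4 (1.04 log units; beyond the scatter). The change is (dimethylamino)methyl in place of hydrogen on a saturated ring carbon of a six-membered non-aromatic ring of carbon only, a place that stays the same across compound 1, compound 2 and compound 3, whose halogen steps on the aromatic end cannot be read. Compound 4 is also the only compound shown with an exact number, while the other three remain at one limit: the limit of > 50000 nM in this assay, at which 3 of the 4 values shown sit.

The compounds shown leave open whether another group on this ring carbon, such as a plain methyl, a (diethylamino)methyl or a morpholinomethyl, would give a step of similar size, and so whether the nitrogen of the amine or the added carbon matters more. They also leave open whether (dimethylamino)methyl on the same ring carbon would bring compound 2 and compound 3 away from their limit as it did for compound 1.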